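A few compounds are considered here, and "the series" means these few. Any claim that something is new, unique, unknown or untested is made for them only; others in the source may bear on it.

Of the compounds shown here, three have so far been measured in an assay on membranes from brain (Cavia porcellus) for binding affinity to Sigma non-opioid intracellular receptor 1 (Homo sapiens), read by radioligand binding; a higher number here means a weaker inhibitor, a lower number a stronger inhibitor. Compound 1 `N=C(Nc1ccc(Br)cc1)Nc1ccc(Br)cc1` gives 33 nM in this assay. Compound 2 `CCc1cccc(NC(=N)N(C)c2cccc3ccccc23)c1` gives 1000 nM in the same assay, and compound 3 `N=C(Nc1cccc2ccccc12)N1CCCCC1` gives 1070 nM. On these numbers compound 3 sits at the upper end together with compound 2, whose value lies within the usual scatter of it, while compound 1 stands well below both, a gap that lies beyond the scatter.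

Compound 4 `N=C(Nc1cccc2ccccc12)N1CCC(c2ccccc2)CC1` has not yet been measured in this assay. It differs from compound 3 in a single place: phenyl in place of hydrogen on a saturated ring carbon. Going by the values given here, no pair of measured compounds differs by exactly this change, so nothing among them fixes the size of such a step; the piece can only weigh the change itself. A phenyl entering on the saturated ring of compound 3 is a sizeable addition, and the author expects it to lower the number somewhat, that is, to strengthen binding, with the step of a 3.1-fold lower number from compound 3 to compound 4 (0.49 log units; beyond the scatter) read as the expected effect of the change. The author's estimate for compound 4 in this assay is 350 nM, with a range from 100 nM to 1200 nM.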

Compound 4, half-maximal inhibitory concentration: 343 nM
The estimate for compound 4 lay 1.0-fold (0.01 log units) above the measured number; the range from low to high includes it.
By their numbers in this assay, from the lowest: compound 1; then compound 4; then compounds 2 and 3 (each within the scatter of the next).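

In this assay the step of a 3.1-fold lower number from compound 3 to compound 4 (0.49 log units; beyond the scatter) is the first measured effect of a single change among these compounds, as no earlier pair differed in one place only. It shows that the saturated ring of compound 3 can carry a phenyl in place of hydrogen on a saturated ring carbon, three ring bonds from the ring nitrogen, and that this sizeable all-carbon addition, with no hydrogen-bond donors or acceptors, strengthens binding rather than weakening it. No measurement at hand speaks to the reason for this step.

The compounds shown leave open whether it is the phenyl ring itself that matters at this place, or whether a smaller group such as methyl, a longer link such as benzyl, or a group such as a hydroxyl, an amine or a carboxylic acid would move the number in the same direction. They also leave open whether a phenyl on another carbon of the saturated ring would have a step of similar size, and whether a substituent on the phenyl would add to it.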